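From Phenyl to Pyridin-2-yl on a Sulfonyl Sulfur

This account rests on a few compounds, and the source may have more. Where it says the series, first, only, none or still open, it means among the compounds named here.

Measured so far in an ADME assay (liver) for metabolic stability, with Liver microsome (Homo sapiens) as the target, read by LC-MS, using microsomes and NADPH, with a stated time of 5 min, at 37 degrees C; on this read-out lower numbers stand for slow clearance and higher numbers for fast clearance
compound 1 `CCn1c(C(C)NS(=O)(=O)c2ccc(Cl)cc2)nc2ccncc21` gives 93 mL.min-1.g-1
compound 2 `CCn1c(C(C)NS(=O)(=O)c2ccc(Cl)cc2)nc2ncccc21` gives 15 mL.min-1.g-1
compound 3 `CCn1c([C@@H](C)NS(=O)(=O)c2ccccc2)nc2ccc(C(F)(F)F)cc21` gives 14 mL.min-1.g-1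

In this assay, compound 3 at 14 mL.min-1.g-1 stands within the scatter of compound 2 at 15 mL.min-1.g-1. Compound 1, at 93 mL.min-1.g-1, gives a clearly higher number than compound 3, and that gap lies beyond the scatter.

Compound 4 `CCn1c([C@@H](C)NS(=O)(=O)c2ccccn2)nc2ccc(C(F)(F)F)cc21` has not yet been measured. It differs from compound 3 in one place, with pyridin-2-yl in place of phenyl on a sulfonyl sulfur. Going by the values given here, no pair of measured compounds differs in only one place, so the data give no direct guide to the size of this step. Compound 1 at 93 mL.min-1.g-1 and compound 2 at 15 mL.min-1.g-1 lie far apart, so a larger move cannot be ruled out.

The expected change is small and towards slower clearance, probably staying within the scatter, and the estimate is a 1.3-fold lower number from compound 3 to compound 4 (0.10 log units; within the scatter). In this assay, the expected value for compound 4 is 11 mL.min-1.g-1, with an estimated range from 5 mL.min-1.g-1 to 24 mL.min-1.g-1.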

Compound 4, intrinsic clearance in microsomes: < 3 mL.min-1.g-1
Compound 4 ended at the assay's limit; the forecaster's own chance of this, stated with the estimate: 5%; middle value at least 3.6-fold (0.56 log units) from the limit.
By their numbers in this assay, from the lowest: compounds 3 and 2 (each within the scatter of the next); then compound 1. At a limit, below all of these: compound 4.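

Read in this assay, the step is the first in this set that isolates a single change: with pyridin-2-yl in place of phenyl on a sulfonyl sulfur, the result is an at least 4.6-fold lower number from compound 3 to compound 4 (0.66 log units; beyond the scatter). So a ring of carbon only giving way to a ring with one nitrogen, at this one place and with the rest of compound 3 untouched, is enough to carry the number beyond the scatter, a move that the earlier compounds could not attribute to any single change. Compound 4 gives < 3 mL.min-1.g-1, which is a limit of the assay and not a number, so the step has a known lower bound but no known full size: the limit of < 3 mL.min-1.g-1 in this assay, at which 1 of the 4 values shown sits.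

The compounds shown do not tell whether the ring nitrogen must sit as it does in pyridin-2-yl, since neither pyridin-3-yl nor pyrimidin-2-yl appears at this sulfonyl sulfur. They also leave open whether the same exchange would lower the number on the cores of compound 1 and compound 2, which carry a chlorine on their phenyl ring, and they give no cause for the step.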